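The source may hold more compounds than are shown below. What is called first, only, known or untested is meant among the compounds shown, and "the series" means these compounds.

All three measured compounds were tested in an assay on RBL-1 cells for inhibition of Polyunsaturated fatty acid 5-lipoxygenase (Rattus norvegicus); a lower number here means a stronger inhibitor, a higher number a weaker inhibitor.

Compound 1, `O=C1NCCN(c2cccc(F)c2)N1`, gives 19000 nM
Compound 2, `CC1CN(c2cccc(F)c2)NC(=O)N1`, gives 6300 nM
Compound 3, `O=C1NCCN(c2cccc(Cl)n2)N1`, gives 5600 nM

Compound 1 and compound 2 share the same core and differ in a single place: methyl in place of hydrogen on a saturated ring carbon. That change produced a 3.0-fold lower number from compound 1 to compound 2 (0.48 log units; beyond the scatter), a step that lies beyond the usual scatter of this assay. Compound 3 is built on a different core; the difference between the cores of compound 1 and compound 3 is not broken down here. Compound 3 has the lowest of the three numbers, but its gap to compound 2 falls within the scatter, so the two cannot be ranked against each other, whereas its gap to compound 1 is beyond the scatter.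

Compound 4, `CC1CN(c2cccc(Cl)n2)NC(=O)N1`, has not yet been measured. It differs from compound 3 in one place: methyl in place of hydrogen on a saturated ring carbon. This is the same change, at the same place on the ring, that turns compound 1 into compound 2. For the measured compounds named here, the expectation for compound 4 therefore rests on the one precedent, a 3.0-fold lower number from compound 1 to compound 2 (0.48 log units; beyond the scatter), and the step from compound 3 to compound 4 is expected to be of similar size, a 2.8-fold lower number from compound 3 to compound 4 (0.45 log units; beyond the scatter). Since this rests on a single pair, the range is kept wide. Compound 4 is estimated at 2000 nM in this assay, with a likely span from 1000 nM to 5000 nM.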

Compound 4, half-maximal inhibitory concentration: 3500 nM
Estimate against measurement, compound 4: 1.8-fold (0.24 log units) below, and the stated range covers the measured number.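

In this assay, methyl in place of hydrogen on a saturated ring carbon gives a 1.6-fold lower number from compound 3 to compound 4 (0.20 log units; within the scatter), so on this second core the step alone cannot be told apart from the ordinary spread of repeated measurements. Set beside the earlier step, the result on this core is no different from the one on the first core, as far as the assay can tell: the same change on two cores in this assay, a 3.0-fold lower number (0.48 log units; beyond the scatter) from compound 1 to compound 2 and a 1.6-fold lower number (0.20 log units; within the scatter) from compound 3 to compound 4, 1.9-fold (0.28 log units) apart, within the scatter of two such steps. This fits the idea that the change carries over from one core to the other at a similar size, but it does not prove it: one of the two steps lies within the scatter, and two pairs of compounds cannot fix the size of the step or set a rule for any other core.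

The compounds shown leave open whether something other than methyl on the same saturated ring carbon, such as an ethyl group, a longer chain, an amine or a carboxylic acid, would give a step like these. They also leave open how the methyl would behave on a core whose aromatic ring carries a different group, such as a nitrile, in place of the fluorine or chlorine seen here.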